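This account rests on a few compounds, and the source may have more. Where it says the series, first, only, none or still open, it means among the compounds named here.

Compound 1 `Cc1ccc(-c2nn(-c3ccc(Cl)cc3)cc2/C=N\c2ccc(Cl)cc2)cc1` gives 49.2% in a functional assay on the whole organism (strain Wistar albino) for inhibition, with Rattus norvegicus as the target, read by paw edema, with stated times of 1 h and 3 h, at a dose of 0.32 mmol/kg by the intraperitoneal route; a higher number here means more inhibition at the dose given (going by the name of the read-out), a lower number less inhibition. Compound 2 `COc1ccc(-c2nn(-c3ccc(Cl)cc3)cc2C(CC(=O)c2ccc(Cl)cc2)C(=O)c2ccc(F)cc2)cc1` gives 37.8%. Compound 3 `COc1ccc(C(=O)C(CC(=O)c2ccc(Cl)cc2)c2cn(-c3ccc(Cl)cc3)nc2-c2ccc(OC)cc2)cc1` gives 9.61%.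

Compound 2 stands second of the three: compound 1 lies higher by a margin beyond the scatter, and compound 3 lies lower, the step being a number 28.2 percentage points lower from compound 2 to compound 3 (beyond the scatter). Compound 4 `COc1ccc(-c2nn(-c3ccc(S(N)(=O)=O)cc3)cc2C(CC(=O)c2ccc(Cl)cc2)C(=O)c2ccc(F)cc2)cc1` differs from compound 2 in one place: sulfamoyl in place of chloro on an aromatic carbon. For the measured compounds named here, the single measured step, from compound 2 to compound 3, concerns methoxy in place of fluoro on an aromatic carbon, a different change, so no measured step bears on sulfamoyl replacing chloro. The step expected for compound 4 in this assay is therefore a number 2.2 percentage points higher from compound 2 to compound 4 (within the scatter), within the scatter, with a wide range. Compound 4 is estimated at 40%, between 20% and 60%.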

Compound 4, a percentage reported as inhibition, in the whole organism at one dose (the size of the read-out at that dose, not a potency): 68.1%
The estimate for compound 4 lay 28.1 percentage points below the measured number, and the stated range ends below it.
By their numbers in this assay, from the lowest: compound 3; then compound 2; then compound 1; then compound 4.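

Replacing 4-chlorophenyl with 4-sulfamoylphenyl gives a number 30.3 percentage points higher from compound 2 to compound 4 (beyond the scatter) in this assay, so this place on the ring, para to a large group, is one where a change can raise the read-out. The earlier step, at a different place, showed only a fall, while here four heavy atoms replace one without any loss. Nothing shown explains the rise.

As far as these compounds go, whether an amine or a carboxylic acid at this place would do the same remains open. So does whether sulfamoyl brings a similar rise on the methoxy-bearing compound 3.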